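The source may report more compounds than this note shows. Statements on the series, on what has been measured and on what is new or still open speak of the compounds shown alone.

Measured so far in an assay on microsomes from brain for inhibition of Fatty-acid amide hydrolase 1 (Rattus norvegicus), read by fluorescence and HPLC, with a stated time of 60 min; a higher number here means a weaker inhibitor, a lower number a stronger inhibitor:
- compound 1, `CCCCCCCCc1ccc(OCC(=O)Cn2nnc(-c3ccc(C(=O)O)cc3)n2)cc1`: 90 nM
- compound 2, `CCCCCCCCc1ccc(OCC(=O)Cn2nnc(-c3cccc(C(=O)O)c3)n2)cc1`: 36 nM
- compound 3, `CCCCCCCCc1ccc(OCC(=O)Cn2nnnc2-c2ccc(C(=O)O)cc2)cc1`: 3400 nM

Compounds 1 and 2 share one core; compound 3 carries the same atoms joined differently. The difference between the two cores is not broken down here. What the values show is that compound 3 stands highest of the three: compound 1 gives a number that is far lower, and compound 2 lower still.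

Within the first core the single change from compound 1 to compound 2 is 3-carboxyphenyl in place of 4-carboxyphenyl on an aromatic carbon. In this assay this gave a 2.5-fold lower number from compound 1 to compound 2 (0.40 log units; beyond the scatter).

Compound 4, `CCCCCCCCc1ccc(OCC(=O)Cn2nnnc2-c2cccc(C(=O)O)c2)cc1`, is not yet measured. It differs from compound 3 by 3-carboxyphenyl in place of 4-carboxyphenyl on an aromatic carbon. Within the data shown here, this is the same kind of change as the one from compound 1 to compound 2, but not the same: in compound 1 the site is two ring bonds from the ring nitrogen and two ring bonds from the ring atom that bears a large group, whereas in compound 3 it is next to the ring atom that bears a large group and two ring bonds from the ring nitrogen. One earlier example on a different core is a thin basis, so the expectation is held loosely.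

Among the measured compounds shown here, for compound 4 in this assay the expected step is a 1.9-fold lower number from compound 3 to compound 4 (0.28 log units; within the scatter), set beside a 2.5-fold lower number from compound 1 to compound 2 (0.40 log units; beyond the scatter) as its only precedent, and kept somewhat smaller given the changed surroundings of the site. Compound 4 is therefore estimated at 1800 nM, with a plausible range from 600 nM to 5500 nM.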

Compound 4, half-maximal inhibitory concentration: 1800 nM
Beside the measured number, compound 4's estimate shows no gap at the digits printed; measured number inside the range.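

In this assay, 3-carboxyphenyl in place of 4-carboxyphenyl on the core of the later pair gives a 1.9-fold lower number from compound 3 to compound 4 (0.28 log units; within the scatter), which by itself does not separate the two compounds. Set beside the same change on the core of compound 1, the size of the step cannot be told apart between the two cores: the same change on two cores in this assay, a 2.5-fold lower number (0.40 log units; beyond the scatter) from compound 1 to compound 2 and a 1.9-fold lower number (0.28 log units; within the scatter) from compound 3 to compound 4, 1.3-fold (0.12 log units) apart, within the scatter of two such steps. This is one pair per core in a single assay, so it shows agreement between two cores and no rule for the series, and it does not show that the change has a real effect on the core of compound 3.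

Open, going by these compounds, is how a methyl ester or a primary amide in place of the carboxylic acid would read on either core, and whether the step from 4-carboxyphenyl to 3-carboxyphenyl would survive such a replacement. Equally open, on these data alone, is whether the step would hold with a shorter chain in place of the octyl chain, or with an alcohol in place of the ketone carbonyl.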